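Swapping a Hydroxy for a Methyl on a Shared Core

This account rests on a few compounds, and the source may have more. Where it says the series, first, only, none or still open, it means among the compounds named here.

Of the compounds shown here, three built on one shared core have been tested in a functional assay on A549 cells (Homo sapiens) for inhibition, read by MTT assay, with a stated time of 72 h; on this read-out lower numbers stand for stronger inhibition and higher numbers for weaker inhibition. Compound 1 `CC(O)c1cn(Cc2cc(=O)oc3cc(O)ccc23)nn1` gave no number in this assay: its result is a limit, > 100000 nM. This result is the limit of > 100000 nM in this assay, at which 1 of the 3 values shown sits. Compound 2 `O=c1cc(Cn2cc(CNS(=O)(=O)c3ccc(Cl)cc3)nn2)c2ccc(O)cc2o1` gives 47900 nM in this assay. Compound 3 `O=c1cc(Cn2cc(-n3ccc4cc(I)ccc43)nn2)c2ccc(O)cc2o1` gives 28600 nM in this assay; the number for compound 2 lies within the usual scatter of that for compound 3, so the two cannot be told apart. Compound 1 offers only a limit for comparison.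

Compound 4 `Cc1ccc2c(Cn3cc(-n4ccc5cc(I)ccc54)nn3)cc(=O)oc2c1` has not yet been measured. It differs from compound 3 in one place: methyl in place of hydroxy on an aromatic carbon, a methyl in place of hydroxy on an aromatic carbon. Among the measured compounds shown here, no pair of measured compounds shows a step of this kind, so there is nothing to lean on beyond compound 3 itself. The step from compound 3 to compound 4 is expected to be small, a 1.0-fold higher number from compound 3 to compound 4 (0.02 log units; within the scatter), with no clear direction and not beyond the scatter. Compound 4 is therefore expected to give about 30000 nM in this assay, within a range from 8000 nM to 100000 nM.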

Compound 4, half-maximal inhibitory concentration: 34100 nM
Estimate against measurement, compound 4: 1.1-fold (0.06 log units) below, within the range that was stated.
By their numbers in this assay, from the lowest: compounds 3, 4 and 2 (each within the scatter of the next). At a limit, above all of these: compound 1.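

In this assay, replacing the hydroxy with a methyl on this aromatic carbon gives a 1.2-fold higher number from compound 3 to compound 4 (0.08 log units; within the scatter). Among the compounds shown here, this is the first step measured at a single place, and it shows that, with the iodo-bearing side chain of compound 3 in place, losing this hydroxy, with its hydrogen-bond donor and acceptor, leaves no change that can be told from the scatter. Nothing among the measurements shown explains why this swap makes so little difference.

From the compounds shown here alone, how an amine, a carboxylic acid or a longer chain would read at this same position remains open. For the compounds shown here, it is also open whether the swap from hydroxy to methyl would read the same way with a different side chain, such as the one on compound 2.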